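This account rests on a few compounds, and the source may have more. Where it says the series, first, only, none or still open, it means among the compounds named here.

Series notes, shared core as in compound 1 `c1ccc(-c2cn3ccnc3c(-c3ccc4ncn(C5CCCCC5)c4c3)n2)cc1`. In a functional assay on HCT-15 cells (Homo sapiens) for inhibition, read by sulforhodamine B assay, with a stated time of 48 h, tested at 10 uM (on this read-out lower numbers stand for less inhibition and higher numbers for more inhibition at the one concentration tested (going by the name of the read-out)), compound 1 gives 51.6%. Compound 2 `Fc1ccc(-c2cn3ccnc3c(-c3ccc4ncn(C5CCCCC5)c4c3)n2)cc1` carries fluoro in place of hydrogen on an aromatic carbon, and in this assay compound 2 gives 7.59%; the step of a number 44 percentage points lower from compound 1 to compound 2 (beyond the scatter). For the measured compounds named here, compound 2 therefore stands lowest of the two numbers so far, with compound 1 as its only neighbour.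

Compound 3 `CC(=O)c1ccc(-c2cn3ccnc3c(-c3ccc4ncn(C5CCCCC5)c4c3)n2)cc1` is the next case: acetyl in place of fluoro on an aromatic carbon. Going by the values given here, no measured step covers an acetyl group, so the one step available bears only indirectly, showing that this aromatic carbon, para to a large group, is a position where a single change moved the read-out by a large amount. Whether acetyl behaves like hydrogen or like fluoro there cannot be told from the numbers; the expectation is a step of a number 20.4 percentage points higher from compound 2 to compound 3 (beyond the scatter), with wide uncertainty. Compound 3 is thus estimated at 28%, in a range from 2% to 60%.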

Compound 3, a percentage reported as inhibition, at one concentration (the size of the read-out at that concentration, not a potency): 18.8%
Estimate against measurement, compound 3: 9.2 percentage points above, within the range that was stated.
By their numbers in this assay, from the lowest: compound 2; then compound 3; then compound 1.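

In this assay, the lower number at this aromatic carbon, para to a large group, is not confined to fluoro: acetyl in place of hydrogen gives a number 32.8 percentage points lower from compound 1 to compound 3 (beyond the scatter), leaving the unsubstituted phenyl of compound 1 highest of the three. The two substituents are still distinguishable, as acetyl in place of fluoro gives a number 11.2 percentage points higher from compound 2 to compound 3 (beyond the scatter), which recovers only part of the loss seen with fluoro. No available evidence accounts for the lower numbers or for the gap between the two substituents.

From the compounds shown here alone, whether an amine, a carboxylic acid or a longer alkyl chain at this carbon would also fall below compound 1, or match or exceed it, remains open. Also open, going by these compounds, is whether this order would hold at other concentrations.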